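A few compounds are considered here, and "the series" means these few. Any claim that something is new, unique, unknown or untested is made for them only; others in the source may bear on it.

Measured so far:
- Compound 1 `CC(C)n1nc(-c2cccnc2)c2ccccc2c1=O` gives 3090 nM
- Compound 2 `C=CCn1nc(-c2cccnc2)c2ccccc2c1=O` gives 2140 nM

For the measured compounds named here, in a functional assay (trachea) with Cavia porcellus as the target (a lower number here means a stronger inhibitor, a higher number a weaker inhibitor), compound 1 gives 3090 nM and has only one neighbour for comparison. That neighbour is compound 2, and the comparison, a 1.4-fold lower number from compound 1 to compound 2 (0.16 log units; within the scatter), puts the two level, so neither can be called the better inhibitor.

The next structural change leaves the isopropyl group in place. Compound 3 `CC(C)n1nc(-c2cncs2)c2ccccc2c1=O` keeps the core of compound 1 and differs as follows: 1,3-thiazol-5-yl in place of pyridin-3-yl on an aromatic carbon. Going by the values given here, the only measured step was allyl in place of isopropyl on an aromatic nitrogen, a change at a different place on the molecule. Among the compounds with values here, it offers no direct guide here, and nothing measured so far tests a replacement of pyridin-3-yl. The safest expectation in this assay is therefore no shift beyond the scatter, in either direction, though with real uncertainty. The expected step is a 1.0-fold lower number from compound 1 to compound 3 (0.01 log units; within the scatter) and it remains an estimate. For compound 3 the estimated value is 3000 nM, with an expected range from 800 nM to 11000 nM as its limits.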

Compound 3, half-maximal inhibitory concentration: 3390 nM
For compound 3 the middle estimate is 1.1-fold (0.05 log units) below the measured one; low and high end bracket the measured number.
By their numbers in this assay, from the lowest: compounds 2, 1 and 3 (each within the scatter of the next).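

In this assay, replacing one aromatic ring with another at this position gives a 1.1-fold higher number from compound 1 to compound 3 (0.04 log units; within the scatter), so the read-out does not separate the six-membered pyridin-3-yl from the five-membered 1,3-thiazol-5-yl, which brings sulfur into the molecule. The earlier comparison varied only the group on the ring nitrogen, whereas this one shows that, for these two rings, a change in ring size and in the number of hetero atoms on the aromatic carbon leaves the number within the scatter. No supporting measurement is available to explain why these two rings read alike, so this remains a plain observation.

Going by these compounds, both rings are small aromatic rings containing nitrogen, so it remains open whether a plain phenyl ring, or a non-aromatic group such as a carboxylic acid or a primary amine, would hold the number at this position or move it beyond the scatter. On these data alone, it also remains open whether 1,3-thiazol-5-yl would read the same with allyl on the ring nitrogen, or with a longer chain there.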